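The source may report more compounds than this note shows. Statements on the series, on what has been measured and on what is new or still open speak of the compounds shown alone.

Measured compounds:
- compound 1, `CC(C)[C@@H]1CC[C@@H](C)C[C@@]12N(C)C(=O)[C@@H]1[C@H]3C(=O)N(c4ccc(Cl)cc4)C(=O)[C@H]3ON12`, gives 53.7% in a functional assay, read by spectrophotometry, with a stated time of 2 h, tested at 1 mg/mL; on this read-out higher numbers stand for a stronger effect at the one concentration tested and lower numbers for a weaker effect
- compound 2, `COc1ccc(N2C(=O)[C@H]3[C@H](ON4[C@@H]3C(=O)N(C)[C@@]43C[C@H](C)CC[C@H]3C(C)C)C2=O)cc1`, gives 50% in this assay
- compound 3, `Cc1ccc(N2C(=O)[C@H]3[C@H](ON4[C@@H]3C(=O)N(C)[C@@]43C[C@H](C)CC[C@H]3C(C)C)C2=O)c(C)c1`, gives 53.1% in this assay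

All three share one core and differ only in the aromatic group on an amide-type nitrogen in a ring. Compound 3 sits second highest of the three numbers, but its gap to compound 1 and its gap to compound 2 both lie within the scatter, so the three values cannot be ranked with confidence.

Compound 4, `CC(C)[C@@H]1CC[C@@H](C)C[C@@]12N(C)C(=O)[C@@H]1[C@H]3C(=O)N(c4ccc5ccccc5c4)C(=O)[C@H]3ON12`, carries a larger aromatic group in that position: naphthalen-2-yl in place of 2,4-dimethylphenyl on an amide-type nitrogen in a ring.

Going by the values given here, the steps that bear on this change are those that also swap the aromatic group on that nitrogen. They were a number 0.6 percentage points lower from compound 1 to compound 3 (within the scatter) and a number 3.1 percentage points higher from compound 2 to compound 3 (within the scatter), and likewise a number 3.7 percentage points lower from compound 1 to compound 2 (within the scatter). None of them moved this assay beyond the scatter, which suggests that this position tolerates different aromatic groups without a large shift in the read-out. Among the compounds with values here, no measured step goes as far as a two-ring aromatic group, so the expectation for compound 4 rests on the assumption that this tolerance continues.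

Compound 4 is therefore expected to show a step of a number 1.1 percentage points lower from compound 3 to compound 4 (within the scatter), no larger than the scatter, in either direction. Compound 4 is estimated at 52%, within the range 38% to 66%.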

Compound 4, a percentage reported as activity, at one concentration (the size of the read-out at that concentration, not a potency): 29.6%
Estimate against measurement, compound 4: 22.4 percentage points above, outside the stated range (below it).
By their numbers in this assay, from the lowest: compound 4; then compounds 2, 3 and 1 (each within the scatter of the next).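

Going by these compounds alone, replacing a single aromatic ring with naphthalen-2-yl on this amide-type nitrogen is the first change here to move the read-out in this assay beyond the scatter, and the fall appears against all three single-ring compounds (a number 23.5 percentage points lower from compound 3 to compound 4 (beyond the scatter)) (a number 20.4 percentage points lower from compound 2 to compound 4 (beyond the scatter)) (a number 24.1 percentage points lower from compound 1 to compound 4 (beyond the scatter)). The 4-chlorophenyl, 4-methoxyphenyl and 2,4-dimethylphenyl groups stay within the scatter of one another, so the tolerance seen earlier holds among these single-ring groups but does not extend to naphthalen-2-yl, with its 2 six-membered aromatic rings. No measurement available here explains why the second ring comes with this lower number.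

Within the data shown here, with only one two-ring group in the set, it remains open whether the fall belongs to naphthalen-2-yl alone or to two-ring groups more widely. Naphthalen-1-yl, quinolin-6-yl or biphenyl-4-yl on the same nitrogen could help separate these possibilities, while 4-aminophenyl or 4-carboxyphenyl would show how a single ring bearing an amine or a carboxylic acid compares with the three single-ring groups.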